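This account rests on a few compounds, and the source may have more. Where it says the series, first, only, none or still open, it means among the compounds named here.

Measured in an assay on cells for displacement of a labelled ligand from Orexin receptor type 2 (Homo sapiens), read by scintillation counting, with stated times of 10 min and 90 min, tested at 10 uM; on this read-out higher numbers stand for more inhibition at the one concentration tested (going by the name of the read-out) and lower numbers for less inhibition:
compound 1 `COC(=O)c1cccc2c(C(=O)c3ccccc3)cc(C(=O)c3ccc(C(Cl)(Cl)Cl)cc3)c-2c1` gives 27%
compound 2 `O=C(O)c1cccc2c(C(=O)c3ccccc3)cc(C(=O)c3ccc(C(Cl)(Cl)Cl)cc3)c-2c1` gives 25.6%
compound 3 `COC(=O)c1ccc2c(C=O)cc(-c3ccccc3)c-2cc1` gives 1.8%

Compound 1 and compound 2 share one core. The change between them is hydrogen in place of methyl on an oxygen next to a carbonyl group, and the step it made, a number 1.4 percentage points lower from compound 1 to compound 2 (within the scatter), lies within the scatter. Compound 3 is built on another core; how the core of compound 3 differs from the core of compound 1 is not broken down here. In this assay compound 3 sits lowest of the three, with compound 2 and compound 1 both beyond the scatter above it.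

Compound 4 `O=Cc1cc(-c2ccccc2)c2ccc(C(=O)O)ccc1-2` is not yet measured. It derives from compound 3 by hydrogen in place of methyl on an oxygen next to a carbonyl group, the same change as from compound 1 to compound 2, made at the same place. Because the earlier step of a number 1.4 percentage points lower from compound 1 to compound 2 (within the scatter) stayed within the scatter, compound 4 is expected to stay close to compound 3 in this assay. The step expected from this change is a number 0.8 percentage points lower from compound 3 to compound 4 (within the scatter). The estimate for compound 4 in this assay is 1%, expected to fall between -8% and 10%.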

Compound 4, a percentage reported as inhibition, at one concentration (the size of the read-out at that concentration, not a potency): 21.5%
Compound 4: middle estimate off by 20.5 percentage points, on the low side; measured number above the stated range.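

In this assay, methoxycarbonyl to carboxy gave a number 19.7 percentage points higher from compound 3 to compound 4 (beyond the scatter), so the change does not carry over with a constant effect from one core to the other: the same change on two cores in this assay, a number 1.4 percentage points lower (within the scatter) from compound 1 to compound 2 and a number 19.7 percentage points higher (beyond the scatter) from compound 3 to compound 4, 21.1 percentage points apart, beyond the scatter of two such steps

In this series the outcome of the change therefore depends on the core that carries it, with no step outside the scatter on the core of compound 1 and a step beyond it on the core of compound 3. This rests on two pairs only, each read at a single concentration rather than as a potency, and it gives neither a reason for the difference nor a rule for any third core.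

Left open is how an amide or an ethyl ester in the same place would read on either core. Also open, going by these compounds, is whether the larger step on the core of compound 3 would persist if an amine replaced the aldehyde on that core.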